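Fluoro in Place of Methyl: Expected Tolerance of Compound 4

A few compounds are considered here, and "the series" means these few. Any claim that something is new, unique, unknown or untested is made for them only; others in the source may bear on it.

Measured so far:
compound 1 `Cc1ccc2c(c1)/C(=N/NC(=S)Nc1ccccc1)C(=O)N2` — > 25000 nM
compound 2 `O=C1Nc2ccccc2/C1=N/NC(=S)Nc1ccc(Br)cc1` — > 25000 nM
compound 3 `COc1ccccc1NC(=S)N/N=C1\C(=O)Nc2ccccc21` — > 25000 nM

Compound 1 was tested in an ADME assay on RD cells (Homo sapiens) for cytotoxicity (a lower number here means that less compound is tolerated, a higher number that more compound is tolerated), and its result is a limit of the assay, not a number. The result for compound 2 in this assay is likewise a limit. The result for compound 3 in this assay is a limit as well. So compound 1 stands nowhere in particular among the three: all that is known is the limit of > 25000 nM in this assay, at which 3 of the 3 values shown sit, and no order among the compounds can be read from that.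

Compound 4 `O=C1Nc2ccc(F)cc2/C1=N/NC(=S)Nc1ccccc1` has not yet been measured in this assay. It differs from compound 1 in one place: fluoro in place of methyl on an aromatic carbon. Going by the values given here, no measured pair in this set shows what such a swap does to the tolerated concentration, so there is no step from which to read a direction or size.

Given that compound 1 reaches only the limit, the expectation is that compound 4 will also be tolerated up to the limit, with no step beyond the scatter, and the estimated step from compound 1 to compound 4 is a step that the limit leaves unreadable from compound 1 to compound 4. The estimate for compound 4 in this assay is 30000 nM, with a range from 15000 nM to 100000 nM.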

Compound 4, half-maximal cytotoxic concentration: > 25000 nM
Compound 4 gave a limit, no number; the forecaster's own chance of this, stated with the estimate: 85%; the middle value does not contradict the limit.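

Compound 1 and compound 4 each give only a limit in this assay, so no step can be read for fluoro in place of methyl: the limit of > 25000 nM in this assay, at which 4 of the 4 values shown sit.

The compounds shown leave open at what concentration any of them becomes toxic to these cells, and whether fluoro in place of methyl shifts that concentration at all.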